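Methyl for hydrogen: cytotoxicity notes on compounds 1 to 4

The compounds below may be only part of what the source reports. "The series", "measured", "known", "first", "only" and "open" are said of these compounds alone.

Compound 1 `Cn1cnc(CS(=O)(=O)c2ccc(Br)cc2)c1[N+](=O)[O-]` is measured in an ADME assay on THP-1 cells (Homo sapiens) for cytotoxicity, read by flow cytometry and propidium iodide staining, with a stated time of 72 h; on this read-out lower numbers stand for stronger inhibition and higher numbers for weaker inhibition. For compound 1 the value is a limit of the assay, > 694000 nM. Compound 2 `Cc1nc(CS(=O)(=O)c2ccc(Br)cc2)c([N+](=O)[O-])n1C` gives 326000 nM in this assay, which is an at least 2.1-fold lower number from compound 1 to compound 2 (0.32 log units; beyond the scatter); the change is methyl in place of hydrogen on an aromatic carbon. That step is known only as a bound, resting on (the limit of > 694000 nM in this assay, at which 1 of the 3 values shown sits). Compound 3 `Cc1nc(CS(=O)(=O)c2ccccc2)c([N+](=O)[O-])n1CCO` and compound 4 `Cc1ccc(S(=O)(=O)Cc2nc(C)n(CCO)c2[N+](=O)[O-])cc1` carry the same kind of change, but the difference between the two cores is not broken down here. For compound 3 the value in this assay is a limit, > 768000 nM, as the limit of > 768000 nM in this assay, at which 1 of the 3 values shown sits, shows. The change to compound 4 is methyl in place of hydrogen on an aromatic carbon: the methyl enters on a six-membered aromatic ring of carbon only, para to a large group, not on a five-membered aromatic ring with 2 nitrogen between two ring nitrogen atoms, so it is the same kind of change, not the same one. The step expected here is an at least 1.5-fold lower number from compound 3 to compound 4 (0.18 log units; that floor lies within the scatter), set beside the earlier one, which was itself only a bound because an at least 2.1-fold lower number from compound 1 to compound 2 (0.32 log units; beyond the scatter) starts from a limit. Compound 4 is estimated at 500000 nM, within 200000 nM to 1000000 nM.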

Compound 4, half-maximal inhibitory concentration: 59000 nM
For compound 4 the middle estimate is 8.5-fold (0.93 log units) above the measured one; measured number outside the range, below it.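

In this assay, methyl in place of hydrogen on a six-membered aromatic ring of carbon only gives an at least 13-fold lower number from compound 3 to compound 4 (1.11 log units; beyond the scatter). Compound 3 stands at a limit of the assay, > 768000 nM. Both steps point the same way, although the methyl enters a different ring in each, but this does not establish a shared size for the change: the same change on two cores in this assay, an at least 2.1-fold lower number (0.32 log units; beyond the scatter) from compound 1 to compound 2 and an at least 13-fold lower number (1.11 log units; beyond the scatter) from compound 3 to compound 4; the limit leaves it open whether they differ.

Two pairs set no rule for the series. From the compounds shown here alone, it remains open whether another group in the same place, such as an amine or a carboxylic acid, would also give a lower number in this assay.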